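The source may report more compounds than this note shows. Statements on the series, on what has been measured and on what is new or still open speak of the compounds shown alone.

Compound 2 `Nc1nc(N)nc(-c2cc(F)ccc2Cl)n1` stands highest of the two numbers in a functional assay on the whole organism with Rattus norvegicus as the target, at a dose of 20 mg/kg by the intraperitoneal route (a higher number here means more inhibition at the dose given (going by the name of the read-out), a lower number less inhibition), where compound 2 gives 78%. Compound 1 `CS(=O)(=O)c1cccc(-c2nc(N)nc(N)n2)c1` gives -6% in this assay, a number far lower and beyond the scatter. Compound 3 `Nc1nc(N)nc(-c2cccc(F)c2)n1` has not yet been measured. The change from compound 2 to compound 3 is hydrogen in place of chloro on an aromatic carbon. Going by the values given here, no step between measured compounds is known, and neither measured compound shows this change, so the expectation rests on compound 2 alone. A moderate loss is expected, a number 23 percentage points lower from compound 2 to compound 3 (beyond the scatter). Compound 3 is estimated at 55% in this assay, with a range from 20% to 80%.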

Compound 3, a percentage reported as inhibition, in the whole organism at one dose (the size of the read-out at that dose, not a potency): 70%
Estimate against measurement, compound 3: 15 percentage points below; low and high end bracket the measured number.
By their numbers in this assay, from the lowest: compound 1; then compounds 3 and 2 (each within the scatter of the next).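

Hydrogen in place of chloro on this aromatic carbon gives in this assay a number 8 percentage points lower from compound 2 to compound 3 (within the scatter) and so the chloro group is not required for the read-out at this dose. Fluoro in place of methylsulfonyl gives a number 76 percentage points higher from compound 1 to compound 3 (beyond the scatter) and this single change separates compound 1 from compound 3. Nothing measured here explains either step.

As far as these compounds go, it remains open whether a methoxy group or an amine on the carbon that carried chloro would keep this read-out. Compounds with a carboxylic acid in place of the fluoro group are also not among those shown, so that change remains unknown.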